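The source may hold more compounds than are shown below. What is called first, only, known or untested is meant among the compounds shown, and "the series" means these compounds.

Compound 1 `O=C1C=COC(/C=C/c2ccc(C(F)(F)F)cc2)C1` and compound 3 `O=C1C=CCC(/C=C/c2ccc(C(F)(F)F)cc2)N1` both carry an aromatic ring bearing a trifluoromethyl group, attached to two different cores; how the two cores differ is not broken down here. In a functional assay on NCI/ADR cells (Homo sapiens) for inhibition, read by sulforhodamine B assay, with a stated time of 48 h (a higher number here means a weaker inhibitor of growth, a lower number a stronger inhibitor of growth), compound 1 gives 51.6 uM, and compound 3 gives 71.8 uM. These two numbers lie within the usual scatter of each other, so nothing separates them.

Compound 2 `COc1ccc(/C=C/C2CC(=O)C=CO2)cc1` is compound 1 altered at one spot: methoxy in place of trifluoromethyl on an aromatic carbon. In this assay compound 2 gives 239 uM. The change brought a 4.6-fold higher number from compound 1 to compound 2 (0.67 log units; beyond the scatter), so the methoxy compound is a weaker inhibitor of growth than its trifluoromethyl partner.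

Compound 4 `COc1ccc(/C=C/C2CC=CC(=O)N2)cc1` carries the same change made on compound 3: methoxy in place of trifluoromethyl on an aromatic carbon. The place is described in identical words for both pairs, so the change is the same and occurs twice among these compounds, once measured and once not. Within the data shown here, the step for compound 4 in this assay is expected to be a 4.2-fold higher number from compound 3 to compound 4 (0.62 log units; beyond the scatter), because a 4.6-fold higher number from compound 1 to compound 2 (0.67 log units; beyond the scatter) is the only measured example of this change and compound 3 starts close to compound 1. Compound 4 is therefore estimated to give 300 uM, with a likely range from 120 uM to 700 uM. A single precedent is a thin basis, and the outcome for compound 4 remains to be seen.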

Compound 4, concentration for growth inhibition (reported as GI): 842 uM
Compound 4: the middle estimate sits 2.8-fold (0.45 log units) below what was measured; the whole stated range lies below it.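

On the second core, methoxy in place of trifluoromethyl again gives a weaker inhibitor of growth in this assay, with a step (a 12-fold higher number from compound 3 to compound 4 (1.07 log units; beyond the scatter)) in the same direction as on the first core. The second step looks larger by its numbers, but the two steps cannot be told apart, so in this series the change carries over from one core to the other in direction and, as far as the scatter allows, in size: the same change on two cores in this assay, a 4.6-fold higher number (0.67 log units; beyond the scatter) from compound 1 to compound 2 and a 12-fold higher number (1.07 log units; beyond the scatter) from compound 3 to compound 4, 2.5-fold (0.40 log units) apart, within the scatter of two such steps. This does not show why methoxy weakens growth inhibition, and two pairs joining the same two groups cannot establish that the step would hold on any further core.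

The compounds shown compare only trifluoromethyl and methoxy on an aromatic carbon, so they leave open how other groups at that place, such as a chlorine, a nitrile, an amine or a carboxylic acid, would compare on either core. They also leave open whether any group there would give a much stronger inhibitor of growth than the two trifluoromethyl compounds, which remain the stronger member of each pair.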